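A few compounds are considered here, and "the series" means these few. Any claim that something is new, unique, unknown or untested is made for them only; others in the source may bear on it.

Compound 3 `CCN(CC)c1ccc2cc(C(=O)c3ccc(N4CCN(C(=O)CN5CCN(Cc6ccc(C(F)(F)F)cc6)CC5)CC4)cc3)oc2c1` stands highest of the three numbers in a functional assay on A549 cells (Homo sapiens) for cytotoxicity, read by MTT assay, with a stated time of 48 h (on this read-out higher numbers stand for weaker inhibition and lower numbers for stronger inhibition), giving 20100 nM. Its nearest neighbour is compound 1 `CCN(CC)c1ccc2cc(C(=O)c3ccc(N4CCN(C(=O)CN5CCN(S(=O)(=O)C6CC6)CC5)CC4)cc3)oc2c1`, which gives 17300 nM; the furthest is compound 2 `CCN(CC)c1ccc2cc(C(=O)c3ccc(N4CCN(C(=O)CN5CCN(Cc6ccc(/C=C/C(=O)OC)cc6)CC5)CC4)cc3)oc2c1`, which gives 2810 nM.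

The step to compound 4 `CCOC(=O)CN1CCN(CC(=O)N2CCN(c3ccc(C(=O)c4cc5ccc(N(CC)CC)cc5o4)cc3)CC2)CC1` is ethoxycarbonyl in place of 4-(trifluoromethyl)phenyl on a saturated chain carbon bound to an amine nitrogen in a ring. Among the measured compounds shown here, two measured steps bear on it. The step of a 1.2-fold higher number from compound 1 to compound 3 (0.07 log units; within the scatter) shows that exchanging the group on that ring amine nitrogen between a small non-aromatic group and the aryl-methyl group left the number unchanged. The step of a 7.2-fold higher number from compound 2 to compound 3 (0.85 log units; beyond the scatter) shows that the substituent on the aromatic ring of that group can move the number by a modest amount. Compound 4 removes the aromatic ring altogether and carries a small group, as compound 1 does, so the expectation from the step of a 1.2-fold higher number from compound 1 to compound 3 (0.07 log units; within the scatter) is no change beyond the scatter in this assay.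

Compound 4 is therefore estimated at 18000 nM in this assay, within a range of 7000 nM to 45000 nM, an expected step of a 1.1-fold lower number from compound 3 to compound 4 (0.05 log units; within the scatter).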

Compound 4, half-maximal inhibitory concentration: > 40000 nM
Compound 4 gave a limit, no number; the forecaster's own chance of this, stated with the estimate: 5%; middle value at least 2.2-fold (0.34 log units) from the limit.
By their numbers in this assay, from the lowest: compound 2; then compounds 1 and 3 (each within the scatter of the next). At a limit, above all of these: compound 4.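

In this assay compound 4 gives a limit, not a number: the limit of > 40000 nM in this assay, at which 1 of the 4 values shown sits.

With (ethoxycarbonyl)methyl on the ring amine nitrogen, the clearest reading is an at least 14-fold higher number from compound 2 to compound 4 (1.15 log units; beyond the scatter), whereas the reading against 4-(trifluoromethyl)benzyl is an at least 1.9-fold higher number from compound 3 to compound 4 (0.29 log units; that floor lies within the scatter), a floor that does not by itself separate the two groups. Among the compounds shown here, the step of an at least 2.3-fold higher number from compound 1 to compound 4 (0.36 log units; beyond the scatter) adds what the earlier compounds did not show: two groups without an aromatic ring need not read alike at this nitrogen, so losing the aromatic ring does not set the number on its own.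

As far as these compounds go, whether the ester matters or only the missing aromatic ring remains open, and a carboxylic acid or a primary amide in place of ethoxycarbonyl would test this. An unsubstituted benzyl group would also show how much of the reading of compound 2 rests on its 2-(methoxycarbonyl)ethenyl substituent.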